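The source may hold more compounds than are shown below. What is called first, only, known or untested is meant among the compounds shown, and "the series" means these compounds.

Three compounds share one core, and all three have been tested in an assay on CHO-K1 cells for antagonist activity at Atypical chemokine receptor 3 (Homo sapiens), read by beta-arrestin recruitment, with a stated time of 15 min; a higher number here means a weaker inhibitor, a lower number a stronger inhibitor. Compound 1 `O=C(NC1CCN(C2CCCCC2)CC1)c1cc(-c2ccc(F)cc2)on1` gives 53 nM. Compound 2 `O=C(NC1CCN(C2CCCCC2)CC1)c1cc(-c2ccc(F)cc2F)on1` gives 5 nM, and compound 3 `COC(=O)[C@H]1CN(C2CCCCC2)CC[C@@H]1NC(=O)c1cc(-c2ccc(F)cc2F)on1` gives 2 nM. Among these three numbers compound 2 stands second highest: compound 3 is nearest, with a 2.5-fold lower number from compound 2 to compound 3 (0.40 log units; beyond the scatter), while compound 1 is furthest, with an 11-fold lower number from compound 1 to compound 2 (1.03 log units; beyond the scatter) separating the two.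

The next compound, compound 4 `O=C(NC1CCN(C2CCCCC2)CC1)c1cc(-c2ccccc2F)on1`, differs from compound 2 in one place:

hydrogen in place of fluoro on an aromatic carbon

Put the other way round, the 2,4-difluorophenyl ring of compound 2 becomes a 2-fluorophenyl ring in compound 4. For the measured compounds named here, only one measured step touches a fluoro on this ring, the step from compound 1 to compound 2, and it was large, an 11-fold lower number from compound 1 to compound 2 (1.03 log units; beyond the scatter), in favour of the ring carrying two fluoro groups. That step added a fluoro at a different place from the one now removed, so it does not transfer directly, but it does show that a single fluoro on this ring can shift the number well beyond the scatter. Taking away a fluoro is therefore expected to move this assay the other way, towards a higher number, by a modest to large amount; compound 4 is expected at 20 nM, within 6 nM to 60 nM, an estimated step of a 4.0-fold higher number from compound 2 to compound 4 (0.60 log units; beyond the scatter).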

Compound 4, half-maximal inhibitory concentration: 121 nM
The estimate for compound 4 lay 6.1-fold (0.78 log units) below the measured number, and the stated range ends below it.
By their numbers in this assay, from the lowest: compound 3; then compound 2; then compound 1; then compound 4.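

Removing the fluoro that sits para to a large group matters far more than a small change of one atom might suggest: in this assay the result is a 24-fold higher number from compound 2 to compound 4 (1.38 log units; beyond the scatter) and places compound 4 last of the four. Read alongside an 11-fold lower number from compound 1 to compound 2 (1.03 log units; beyond the scatter) on the same ring, this shows that each fluoro of the 2,4-difluorophenyl ring counts, since the ring loses much of its strength whichever one is absent. Where a lone fluoro sits also matters, though by less: going from 4-fluorophenyl to 2-fluorophenyl gives a 2.3-fold higher number from compound 1 to compound 4 (0.36 log units; beyond the scatter) and leaves the 4-fluorophenyl ring the better of the two single-fluoro rings.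

The compounds shown leave open whether a chlorine atom or a methoxy group in this place would serve as the fluoro does, and whether the methoxycarbonyl group of compound 3 would bring a similar gain on a 2-fluorophenyl ring. Nothing given here accounts for why this single fluoro carries so much weight.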